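From Phenyl to Dimethylphenyl: Expected Cell Tolerance

The source may report more compounds than this note shows. Statements on the series, on what has been measured and on what is new or still open speak of the compounds shown alone.

For the measured compounds named here, compound 3 `O=C(CSc1snnc1-c1ccc(Br)cc1Br)Nc1ccccc1` is the only compound here with a number rather than a limit in an ADME assay on MT4 cells (Homo sapiens) for cytotoxicity, read by MTT assay, with a stated time of 5 days; a lower number here means that less compound is tolerated, a higher number that more compound is tolerated: compound 3 gives 24800 nM. Compound 1 `Cc1ccc(NC(=O)CSc2snnc2-c2ccc(Br)cc2Br)c([N+](=O)[O-])c1` gives > 229000 nM, which is a limit of the assay and not a number, marking (the limit of > 229000 nM in this assay, at which 1 of the 3 values shown sits). Compound 2 `O=C(CSc1snnc1-c1ccc(Br)cc1Br)Nc1ccccc1F` likewise gives >= 27800 nM, a limit of the assay, marking (the limit of >= 27800 nM in this assay, at which 1 of the 3 values shown sits). Going by the values given here, the one measured step, an at least 1.1-fold lower number from compound 2 to compound 3 (0.04 log units; that floor lies within the scatter), stays within the scatter. Compound 4 `Cc1cccc(NC(=O)CSc2snnc2-c2ccc(Br)cc2Br)c1C` differs from compound 3 by 2,3-dimethylphenyl in place of phenyl on an amide-type nitrogen. Among the compounds with values here, no measured step adds methyl groups, so that single fluoro-to-hydrogen step is the only guide, and it points to no change beyond the scatter. Compound 4 is therefore expected to give 30000 nM, between 12000 nM and 80000 nM, an expected step of a 1.2-fold higher number from compound 3 to compound 4 (0.08 log units; within the scatter).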

Compound 4, half-maximal cytotoxic concentration: 241000 nM
Compound 4: the middle estimate sits 8.0-fold (0.90 log units) below what was measured, and the stated range ends below it.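

On the amide-type nitrogen, 2,3-dimethylphenyl in place of phenyl gives a 9.7-fold higher number from compound 3 to compound 4 (0.99 log units; beyond the scatter) in this assay and so shows that this position can move cell tolerance beyond the scatter, which the fluoro-to-hydrogen step did not show. The step from compound 2 to compound 4 cannot be read. Nothing shown here explains why the two added methyl groups go with this change.

On these data alone, whether a single methyl group on the phenyl ring would be enough stays open. So does whether an amine or a carboxylic acid there would shift the number in the same direction.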